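Methylsulfonyl for sulfamoyl on the methoxy benzothiazole pyrimidine

The source may report more compounds than this note shows. Statements on the series, on what has been measured and on what is new or still open speak of the compounds shown alone.

In a functional assay on MCF7 cells (Homo sapiens) for antiproliferative activity, read by MTT assay, with a stated time of 48 h (a higher number here means a weaker inhibitor, a lower number a stronger inhibitor), the measured compounds stand as follows:
compound 1, `CS(=O)(=O)c1ccc(Nc2ncc(F)c(Nc3nc4ccc(F)cc4s3)n2)cc1`: > 50000 nM, a limit of the assay
compound 2, `COc1ccc2nc(Nc3nc(Nc4ccc(S(N)(=O)=O)cc4)ncc3F)sc2c1`: > 50000 nM, a limit of the assay

Compound 2 stands only at a limit in this assay and gives no number. Compound 1 likewise gives only a limit. Among the compounds with values here, both values therefore sit at the limit of > 50000 nM in this assay, at which 2 of the 2 values shown sit, and no step between measured compounds can be drawn.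

Compound 3, `COc1ccc2nc(Nc3nc(Nc4ccc(S(C)(=O)=O)cc4)ncc3F)sc2c1`, differs from compound 2 by methyl in place of amino on a sulfonyl sulfur. The change joins the sulfonyl group of compound 1 to the core of compound 2, and each of those parents sits at the limit. The expected step is a number no higher from compound 2 to compound 3 (the limit leaves the size open), that is, none beyond the scatter. Compound 3 is accordingly expected to remain at or near the limit, estimated at 50000 nM with a range from 10000 nM to 120000 nM.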

Compound 3, half-maximal inhibitory concentration: 5850 nM
Beside the measured number, compound 3's estimate is 8.5-fold (0.93 log units) above it, outside the stated range (below it).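

In this assay, methyl in place of amino on a sulfonyl sulfur, with the methoxy core held, turns a limit into a measurable value: an at least 8.5-fold lower number from compound 2 to compound 3 (0.93 log units; beyond the scatter). With methylsulfonyl held, methoxy in place of fluoro on an aromatic carbon does the same: an at least 8.5-fold lower number from compound 1 to compound 3 (0.93 log units; beyond the scatter). Of these three compounds, only compound 3 carries both methylsulfonyl and methoxy and only compound 3 gives a number, and both steps are open-ended because compound 1 and compound 2 give only limits: the limit of > 50000 nM in this assay, at which 2 of the 3 values shown sit.

From the compounds shown here alone, whether ethyl or a dimethylamino group on the sulfonyl sulfur keeps this activity stays open. So does the effect of ethoxy or a longer chain in place of methoxy on that aromatic carbon.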